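Methoxycarbonyl for bromo on the side chain

The source may report more compounds than this note shows. Statements on the series, on what has been measured and on what is new or still open speak of the compounds shown alone.

Compound 1 `C#CCn1c2ccc([N+](=O)[O-])cc2c(=O)n1Cc1ccccc1` gives 195000 nM
Compound 2 `O=C(c1ccccc1)n1c2ccc([N+](=O)[O-])cc2c(=O)n1Cc1ccccc1` gives 146000 nM
Compound 3 `O=[N+]([O-])c1ccc2nn(Cc3ccccc3)c(OCCBr)c2c1` gives > 256000 nM as a limit

In an ADME assay on L929 cells (Mus musculus) for cytotoxicity, read by resazurin assay, with a stated time of 48 h (a lower number here means that less compound is tolerated, a higher number that more compound is tolerated), compound 3 stands at > 256000 nM and that is a limit of the assay, not a number. Compound 4 `COC(=O)CCOc1c2cc([N+](=O)[O-])ccc2nn1Cc1ccccc1` carries methoxycarbonyl in place of bromo on a saturated chain carbon, two bonds along the chain from an oxygen on an aromatic ring and the rest of the structure is unchanged. Among the measured compounds shown here, the only measured step is a 1.3-fold lower number from compound 1 to compound 2 (0.13 log units; within the scatter) and it lies at a different place, so it is a loose guide. No step beyond the scatter is expected in this assay in either direction. The expected step is an at least 1.1-fold lower number from compound 3 to compound 4 (0.06 log units; that floor lies within the scatter) on this estimate. For compound 4 the estimate is 220000 nM with an expected range from 110000 nM to 450000 nM for now.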

Compound 4, concentration lethal to 50% of the cells: > 256000 nM
Compound 4 was reported as a limit; the forecaster's own chance of this, stated with the estimate: 45%; middle value at least 1.1-fold (0.06 log units) away from the limit.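

In this assay compound 3 and compound 4 both sit at the assay's limit, so no step between them can be read: the limit of > 256000 nM in this assay, at which 2 of the 4 values shown sit.

Going by these compounds, whether methoxycarbonyl in place of bromo changes how much compound the cells tolerate remains open.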